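Chain-terminal amine swap in a quinone series: compound 4

The compounds below may be only part of what the source reports. "The series", "measured", "known", "first", "only" and "open" are said of these compounds alone.

Three analogues of one shared core have been measured in a toxicity assay on L02 cells (Homo sapiens) for cytotoxicity, read by MTT assay, with a stated time of 72 h; a higher number here means a weaker inhibitor, a lower number a stronger inhibitor. Compound 1 `CN(C)CCCCn1c2c(c3ccccc31)C(=O)c1c[n+]([O-])c3ccccc3c1C2=O` gives 300 nM. Compound 2 `O=C1c2c[n+]([O-])c3ccccc3c2C(=O)c2c1c1ccccc1n2Cc1cn(C[C@H](O)CO)nn1` gives 1130 nM. Compound 3 `O=C1c2c[n+]([O-])c3ccccc3c2C(=O)c2c1c1ccccc1n2CCCCn1ccnc1` gives 150 nM. Compound 3 thus has the lowest of the three numbers, but one of its two separations is a 2.0-fold lower number from compound 1 to compound 3 (0.30 log units; within the scatter), whereas the other is a 7.5-fold lower number from compound 2 to compound 3 (0.88 log units; beyond the scatter). Replacing the dimethylamino end of compound 1 with the hydroxylated triazole of compound 2 gave a 3.8-fold higher number from compound 1 to compound 2 (0.58 log units; beyond the scatter).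

Compound 4 `O=C1c2c[n+]([O-])c3ccccc3c2C(=O)c2c1c1ccccc1n2CCN1CCCCC1` differs from compound 3 by piperidin-1-yl in place of 2-(1H-imidazol-1-yl)ethyl on a saturated chain carbon, two bonds along the chain from an aromatic nitrogen. Going by the values given here, the closest precedent is the step from compound 1 to compound 3, which exchanged dimethylamino for 1H-imidazol-1-yl on the same kind of chain and read a 2.0-fold lower number from compound 1 to compound 3 (0.30 log units; within the scatter). Compound 4 returns to a saturated nitrogen end group of the kind seen in compound 1 rather than the aromatic one in compound 3, so the expected reading lies between compound 1 and compound 3 and no step beyond the scatter is anticipated. For compound 4 in this assay the estimate is 240 nM, with a range of 100 nM to 600 nM, corresponding to an expected step of a 1.6-fold higher number from compound 3 to compound 4 (0.20 log units; within the scatter).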

Compound 4, half-maximal inhibitory concentration: 1050 nM
Estimate against measurement, compound 4: 4.4-fold (0.64 log units) below, outside the stated range (above it).
By their numbers in this assay, from the lowest: compounds 3 and 1 (each within the scatter of the next); then compounds 4 and 2 (each within the scatter of the next).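

In this assay the move to the 2-(piperidin-1-yl)ethyl group gives a 7.0-fold higher number from compound 3 to compound 4 (0.85 log units; beyond the scatter) and a 3.5-fold higher number from compound 1 to compound 4 (0.54 log units; beyond the scatter) and both steps lie beyond the scatter, while a 1.1-fold lower number from compound 2 to compound 4 (0.03 log units; within the scatter) lies within it, so compound 4 reads with compound 2 and apart from compound 1 and compound 3. Going by these compounds alone, a saturated nitrogen end group therefore does not by itself keep a reading close to that of compound 1, which the earlier steps could not show. The same difference cut further out reads 4-(1H-imidazol-1-yl)butyl to 2-(piperidin-1-yl)ethyl, so this change alters the chain as well as the end group, the step cannot be assigned to either alone, and nothing available bears on why the number moves.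

A 4-(piperidin-1-yl)butyl group would hold the chain of compound 3 and change only the end group, and a 2-(1H-imidazol-1-yl)ethyl group would do the reverse. From the compounds shown here alone, whether a morpholin-4-yl end on either chain reads with compound 4 or with compound 3 remains open.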